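Benzamide and cinnamamide thioethers: growth inhibition on HCT-116 cells

A few compounds are considered here, and "the series" means these few. Any claim that something is new, unique, unknown or untested is made for them only; others in the source may bear on it.

Measured so far:
- compound 1 `COc1ccc(SCc2ccc(/C=C/C(=O)Nc3ccccc3N)cc2)cc1OC`: 49.5%
- compound 2 `Nc1ccccc1NC(=O)c1ccc(CSc2nccc(C(F)(F)F)n2)cc1`: 93.1%
- compound 3 `COc1ccc(SCc2ccc(C(=O)Nc3ccccc3N)cc2)cc1`: 90.1%

In a functional assay on HCT-116 cells (Homo sapiens) for inhibition, read by CCK-8 assay, with a stated time of 72 h, tested at 8 uM (a higher number here means more inhibition of growth at the concentration tested, a lower number less inhibition of growth), compound 1 gives 49.5%, the lowest of the three numbers. Compound 3 gives 90.1% and compound 2 gives 93.1%, both beyond the scatter above compound 1. Within the data shown here, no pair of measured compounds differs in only one place, so no single step has been read.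

Compound 4 `CCc1ccc(SCc2ccc(/C=C/C(=O)Nc3ccccc3N)cc2)cc1` is not yet measured in this assay. It differs from compound 1 by 4-ethylphenyl in place of 3,4-dimethoxyphenyl on a sulfur. Among the measured compounds shown here, with no measured step of this kind, an estimated step of a number 10.5 percentage points higher from compound 1 to compound 4 (beyond the scatter) of modest size upward is expected, with wide uncertainty. For compound 4 a value of 60% is estimated, in the range 35% to 85%.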

Compound 4, percent growth inhibition at one concentration: 2.68%
Compound 4: the middle estimate sits 57.3 percentage points above what was measured, and the stated range ends above it.
By their numbers in this assay, from the lowest: compound 4; then compound 1; then compounds 3 and 2 (each within the scatter of the next).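

In this assay the aryl group on the sulfur is a sensitive position in the cinnamamide thioethers: the number is a number 46.8 percentage points lower from compound 1 to compound 4 (beyond the scatter) with 4-ethylphenyl in place of 3,4-dimethoxyphenyl. Among these compounds, this is the first single-place step, and it shows that this one change can take growth inhibition nearly to nothing while the rest of the molecule stays the same. Nothing measured accounts for the size of this drop. Still open, as far as these compounds go, is whether a hydroxyl, an amine or a carboxylic acid on this phenyl ring would hold the number of compound 1 or lose it as well. Also open, from the compounds shown here alone, is whether the same change would cost as much on a benzamide thioether.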